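This account rests on a few compounds, and the source may have more. Where it says the series, first, only, none or still open, it means among the compounds named here.

Compound 1 `COc1cccc2c1ccn2S(=O)(=O)c1ccccc1` is a sulfonyl-linked indole that carries a methoxy on its six-membered carbocyclic ring. In an assay on isolated protein for displacement of a labelled ligand from 5-hydroxytryptamine receptor 6 (Homo sapiens), read by scintillation counting, with a stated time of 1 h (a higher number here means a weaker inhibitor, a lower number a stronger inhibitor), compound 1 gives 262 nM, the highest of the three numbers recorded. Compound 2 `O=S(=O)(c1ccccc1)n1cc(-c2ccccc2)c2ccccc21`, which carries a phenyl on the five-membered ring instead, gives 146 nM, a gap from compound 1 that lies within the scatter. Compound 3 `O=S(=O)(c1ccccc1)n1cc(-c2ccncc2)c2ccccc21` gives 124 nM, and here the gap to compound 1 lies beyond the scatter.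

Compound 4 `O=S(=O)(c1ccccc1)n1ccc2c(-c3ccccc3)cccc21` keeps the core of compound 1 and changes only one place: phenyl in place of methoxy on an aromatic carbon. Within the data shown here, only one measured step touches a change of this kind, the swap a 1.2-fold lower number from compound 2 to compound 3 (0.07 log units; within the scatter), which replaces one aryl group with another on the five-membered ring and leaves the number essentially unchanged. Among the measured compounds shown here, no measured pair exchanges a methoxy for a phenyl, and none alters the six-membered carbocyclic ring of the core, so the direction of the present step is not fixed by the data; compounds 2 and 3 show only that aryl-bearing members of this set give lower numbers than compound 1.

Compound 4 is therefore expected to give 160 nM, within 50 nM to 500 nM, a step of a 1.6-fold lower number from compound 1 to compound 4 (0.21 log units; within the scatter) estimated to stay near the scatter.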

Compound 4, inhibition constant: 162 nM
Compound 4: the middle estimate sits 1.0-fold (0.01 log units) below what was measured, within the range that was stated.
By their numbers in this assay, from the lowest: compounds 3, 2, 4 and 1 (each within the scatter of the next, the first and the last beyond it).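

In this assay, among these compounds, the step of a 1.6-fold lower number from compound 1 to compound 4 (0.21 log units; within the scatter) gives the first reading of a change on an aromatic carbon of the six-membered aromatic ring of carbon only, which the earlier comparison, confined to a swap of one aryl group for another on the five-membered ring, could not provide. At this position, phenyl, with its six heavy atoms and one ring, stands in place of methoxy, with its two heavy atoms and one hydrogen-bond acceptor, and the number stays within the scatter. No available evidence accounts for this result.

The compounds shown leave open whether an amine, a carboxylic acid or a longer alkoxy chain at this position would also stay within the scatter, or would move the number beyond it. They also leave open whether pyridin-4-yl in place of phenyl at this position would repeat what was seen on the five-membered ring, where the step was a 1.2-fold lower number from compound 2 to compound 3 (0.07 log units; within the scatter).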